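Acid head-group variation and rat oral exposure

The source may hold more compounds than are shown below. What is called first, only, known or untested is meant among the compounds shown, and "the series" means these compounds.

For the measured compounds named here, compound 2 `CC(C)CC1(O)CCN(C(=O)Nc2cc(Oc3ccc(F)cc3)cc(Oc3ccc(C4(C(=O)O)CC4)cc3)c2)CC1` gives 320 ng.h/mL in an ADME assay on the whole organism for pharmacokinetics, with Rattus norvegicus as the target, with a stated time of 24 h, at a dose of 1 mg/kg by the oral route; on this read-out lower numbers stand for lower exposure and higher numbers for higher exposure at the dose given; it holds the lowest of the three numbers measured so far. Compound 1 `CC(C)CC1(O)CCN(C(=O)Nc2cc(Oc3ccc(F)cc3)cc(Oc3ccc(CC(=O)O)cc3)c2)CC1` gives 787 ng.h/mL, and compound 3 `CC(C)CC1(O)CN(C(=O)Nc2cc(Oc3ccc(F)cc3)cc(Oc3ccc(C(C)(C)C(=O)O)cc3)c2)C1` gives 1060 ng.h/mL. Compound 3 differs from compound 2 in two places at once, so its value is reported only as it stands.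

The next compound, compound 4 `CC(C)CC1(O)CCN(C(=O)Nc2cc(Oc3ccc(F)cc3)cc(Oc3ccc(C(=O)O)cc3)c2)CC1`, differs from compound 2 in one place: carboxy in place of 1-carboxycyclopropyl on an aromatic carbon.

Going by the values given here, one measured step touches the same position. It reads a 2.5-fold lower number from compound 1 to compound 2 (0.39 log units; beyond the scatter). That step shows a modest loss of exposure on building the three-membered ring onto the acid-bearing carbon; the change to compound 4 removes that ring altogether and leaves the acid directly on the aromatic carbon. Among the compounds with values here, no measured pair shows the bare carboxy group itself, so the direction is inferred from that single step and carries wide uncertainty.

The expected step in this assay is therefore a modest rise, roughly undoing the loss seen from compound 1 to compound 2, but it could equally fall within the scatter. For compound 4 the estimate is 600 ng.h/mL, within a range of 250 ng.h/mL to 1500 ng.h/mL, which corresponds to a step of a 1.9-fold higher number from compound 2 to compound 4 (0.27 log units; within the scatter).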

Compound 4, area under the concentration-time curve: 70 ng.h/mL
Compound 4: the middle estimate sits 8.6-fold (0.93 log units) above what was measured; the measured number lies below the stated range.
By their numbers in this assay, from the lowest: compound 4; then compound 2; then compounds 1 and 3 (each within the scatter of the next).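

In this assay, carboxy in place of 1-carboxycyclopropyl gives a 4.6-fold lower number from compound 2 to compound 4 (0.66 log units; beyond the scatter), and carboxy in place of carboxymethyl gives an 11-fold lower number from compound 1 to compound 4 (1.05 log units; beyond the scatter), so among the three groups compared on this core, the acid set directly on the aromatic carbon gives the lowest number. Exposure at this position does not simply rise as atoms are stripped from the acid side chain: a 2.5-fold lower number from compound 1 to compound 2 (0.39 log units; beyond the scatter) had left open whether the cyclopropane ring was the penalty, yet removing that ring together with the carbon bearing the acid lowers the number further, and both groups with a carbon between the aromatic ring and the acid stand above carboxy. Nothing available on these compounds accounts for the differences.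

On these data alone, whether a longer chain such as 2-carboxyethyl, or a tetrazole in place of the carboxylic acid, would hold or raise exposure remains open. Compound 3 changes the acid side chain and the core together, so the contribution of its two methyl groups on the acid-bearing carbon cannot be separated from the change in the core.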